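Trihalomethylsulfonyl added to a nitroaniline core against WNK1

This account rests on a few compounds, and the source may have more. Where it says the series, first, only, none or still open, it means among the compounds named here.

All values below come from an assay on cells for inhibition of serine/threonine-protein kinase WNK1 (Homo sapiens), read by luminescence and Kinase-Glo, with a stated time of 2 h; a higher number here means a weaker inhibitor, a lower number a stronger inhibitor.
Compound 1, `CCS(=O)(=O)c1ccc(NC2CCCCC2)c([N+](=O)[O-])c1`, gives only the assay limit > 1000000 nM.
Compound 2, `O=[N+]([O-])c1ccccc1NC1CCCCC1`, gives only the assay limit > 1000000 nM.
Compound 3, `O=[N+]([O-])c1cc(S(=O)(=O)C(Cl)(Cl)Br)ccc1Nc1ccccc1`, gives 76000 nM.

Compound 2 stands at a limit, not at a number, and so does one further value of the three shown; this is the limit of > 1000000 nM in this assay, at which 2 of the 3 values shown sit. Within the data shown here, the one comparison that can be drawn, from compound 1 to compound 2, is a step that the two limits leave unreadable from compound 1 to compound 2, so its size is unreadable.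

Compound 4, `O=[N+]([O-])c1cc(S(=O)(=O)C(Cl)(Cl)Cl)ccc1NC1CCCCC1`, is the unmeasured target. It differs from compound 2 by (trichloromethyl)sulfonyl in place of hydrogen on an aromatic carbon. Among the measured compounds shown here, no measured step covers this exact change. Compound 3 carries a related trihalomethylsulfonyl group, and compound 3 gives a measured number, while compound 1 with an ethylsulfonyl group reaches only the limit. On that basis compound 4 is expected to gain some potency, and its step is estimated as an at least 3.3-fold lower number from compound 2 to compound 4 (0.52 log units; beyond the scatter). Compound 4 is therefore estimated at 300000 nM, within 50000 nM to 2000000 nM, with a real chance that this assay reports only a limit.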

Compound 4, half-maximal inhibitory concentration: > 1000000 nM
Compound 4: no number, only a limit (the forecaster's own chance of this, stated with the estimate: 50%); middle value at least 3.3-fold (0.52 log units) away from the limit.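

Compound 4 also gives only a limit, so neither step, from compound 2 to compound 4 or from compound 1 to compound 4, can be read: the limit of > 1000000 nM in this assay, at which 3 of the 4 values shown sit.

The compounds shown leave open how far compound 1, compound 2 and compound 4 truly differ, and which change separates them from compound 3, which differs from each of them in more than one place.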